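Extending the carbamate chain of compound 2

The source may report more compounds than this note shows. Statements on the series, on what has been measured and on what is new or still open speak of the compounds shown alone.

Of the compounds shown here, two of a shared core have been measured for binding to the type-2 angiotensin receptor. Compound 1 `CCCc1nc(CC)c(C(=O)OCc2ccccc2S(=O)(=O)c2ccccc2)n1Cc1ccc(-c2ccccc2S(=O)(=O)NC(=O)OCCC(C)C)cc1F` gives 5 nM in an assay on isolated protein for binding affinity to Type-2 angiotensin II receptor (Homo sapiens); on this read-out higher numbers stand for weaker inhibition and lower numbers for stronger inhibition. Compound 2 `CCCOC(=O)NS(=O)(=O)c1ccccc1-c1ccc(Cn2c(CCC)nc(CC)c2C(=O)OCc2cccc(C(=O)c3ccccc3)c2)c(F)c1` stands with the highest of the two numbers, giving 10 nM in this assay, and its nearest neighbour is compound 1, whose number is lower by a gap that lies within the scatter. Compound 3 `CCCc1nc(CC)c(C(=O)OCc2cccc(C(=O)c3ccccc3)c2)n1Cc1ccc(-c2ccccc2S(=O)(=O)NC(=O)OCCC(C)C)cc1F` is not yet measured. It differs from compound 2 in one place: isopropyl in place of methyl on a saturated chain carbon, two bonds along the chain from an oxygen next to a carbonyl group. The change puts isopropyl in place of methyl on the saturated chain carbon of the carbamate side chain. Because compound 1 already gives 5 nM with the same kind of core, the account expects only a small step, or none beyond the scatter, a 1.4-fold lower number from compound 2 to compound 3 (0.15 log units; within the scatter). For compound 3 the estimated value in this assay is 7 nM, with a range from 3 nM to 20 nM.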

Compound 3, half-maximal inhibitory concentration: 0.9 nM
Estimate against measurement, compound 3: 7.8-fold (0.89 log units) above; the measured number lies below the stated range.
By their numbers in this assay, from the lowest: compound 3; then compounds 1 and 2 (each within the scatter of the next).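

In this assay, isopropyl in place of methyl on a saturated chain carbon, two bonds along the chain from an oxygen next to a carbonyl group, gives an 11-fold lower number from compound 2 to compound 3 (1.05 log units; beyond the scatter) and so a step beyond the scatter. The earlier compounds shown here offered no step to read, and this one shows that the number in this assay responds to a change at this place on the carbamate side chain while the rest of the molecule stays the same. Nothing measured here accounts for the size of this step.

The compounds shown leave open whether the step follows the branching of the chain or only its added carbons, which an unbranched butyl or pentyl group at this place would help to separate. They also leave open whether a hydroxyl group or an amine on this chain would be tolerated, and whether the same change gives a step of this size on the core of compound 1.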